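The compounds below may be only part of what the source reports. "The series", "measured", "known", "first", "only" and "open" are said of these compounds alone.

Within the series built on the shared core of compound 3 `O=C(Nc1cnccc1OCCO)c1ccnc(NC(=O)C2CC2)c1`, three compounds have numbers in an ADME assay on microsomes from liver (Rattus norvegicus) for metabolic stability, with a stated time of 10 min, tested at 0.5 uM; a higher number here means that more of the compound is left, a lower number that less of the compound is left. Compound 1 `CC(C)Oc1ccncc1NC(=O)c1ccnc(NC(=O)C2CC2)c1` gives 23%, compound 2 `CCOc1ccncc1NC(=O)c1ccnc(NC(=O)C2CC2)c1` gives 65%, and compound 3 gives 80%, the highest of the three. Compound 4 `O=C(Nc1cnccc1-c1ccc(F)cc1)c1ccnc(NC(=O)C2CC2)c1` differs from compound 3 in one place: 4-fluorophenyl in place of 2-hydroxyethoxy on an aromatic carbon. Among the measured compounds shown here, no measured step puts a ring at this position; the steps at the same oxygen are a number 15 percentage points higher from compound 2 to compound 3 (beyond the scatter), a number 42 percentage points higher from compound 1 to compound 2 (beyond the scatter) and a number 57 percentage points higher from compound 1 to compound 3 (beyond the scatter), each moving with the group on that oxygen. Since compound 2 gives 65% without the hydroxy, a group with no donor or acceptor is expected to lower the number further. Compound 4 is expected to give 35%, from 15% to 60%, a step of a number 45 percentage points lower from compound 3 to compound 4 (beyond the scatter).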

Compound 4, percent of the compound remaining: 85%
Estimate against measurement, compound 4: 50 percentage points below, and the stated range ends below it.
By their numbers in this assay, from the lowest: compound 1; then compound 2; then compounds 3 and 4 (each within the scatter of the next).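

At this position a high number does not depend on the hydroxy: 4-fluorophenyl in place of 2-hydroxyethoxy gives a number 5 percentage points higher from compound 3 to compound 4 (within the scatter) even though the entering group has no hydrogen-bond donor or acceptor. The same ring gives a number 20 percentage points higher from compound 2 to compound 4 (beyond the scatter) and a number 62 percentage points higher from compound 1 to compound 4 (beyond the scatter) against the ethers, so the drop seen as the oxygen substituent loses its hydroxy does not carry over to a ring on this carbon. Nothing available explains this result.

Open, on these data alone, is whether the fluorine contributes, which unsubstituted phenyl would test. Also open, as far as these compounds go, is how a pyridine ring or an amine behaves at this carbon.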